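This account rests on a few compounds, and the source may have more. Where it says the series, first, only, none or still open, it means among the compounds named here.

Of the compounds shown here, three built on one shared core have been tested in a functional assay on MCF7 cells (Homo sapiens) for inhibition, read by sulforhodamine B assay; a higher number here means a weaker inhibitor, a lower number a stronger inhibitor. Compound 1 `CCCc1ccc(NC2=CC(=O)c3c(nc4n3[C@H]3OC[C@@H](O)[C@H]3OC4)C2=O)cc1` reaches only the limit of the assay there, > 4000 nM. Compound 2 `O=C1C=C(Nc2ccccc2)C(=O)c2c1nc1n2[C@H]2OC[C@@H](O)[C@H]2OC1` likewise stops at a limit, > 4000 nM. Compound 3 `O=C1C(Nc2ccccc2F)=CC(=O)c2c1nc1n2[C@H]2OC[C@@H](O)[C@H]2OC1` also gives no number, only the limit > 4000 nM. The step that the two limits leave unreadable from compound 1 to compound 3 cannot be sized because of the limit of > 4000 nM in this assay, at which 3 of the 3 values shown sit. Compound 4 `COc1ccccc1NC1=CC(=O)c2nc3n(c2C1=O)[C@H]1OC[C@@H](O)[C@H]1OC3` differs from compound 2 by methoxy in place of hydrogen on an aromatic carbon. Among the measured compounds shown here, no measured step bears on a methoxy group, and every value so far is a limit, so the step is expected to be a step that the limit leaves unreadable from compound 2 to compound 4, with compound 4 most likely at a limit once more. Compound 4 is therefore estimated at 6000 nM in this assay, between 2500 nM and 20000 nM.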

Compound 4, half-maximal inhibitory concentration: > 4000 nM
Compound 4 gave a limit, no number (the forecaster's own chance of this, stated with the estimate: 75%); the middle value does not contradict the limit.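

No size can be read for the step between compound 2 and compound 4, because both stop at a limit: the limit of > 4000 nM in this assay, at which 4 of the 4 values shown sit. From the compounds shown here alone, whether any compound on the shared core gives an actual number in this assay stays open.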